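Three inert macrocyclic esters and a fourth awaiting test

The source may hold more compounds than are shown below. What is called first, only, known or untested is meant among the compounds shown, and "the series" means these compounds.

Measured compounds:
- compound 1 `C=C1[C@H](OC(=O)c2ccccc2)[C@H]2[C@@H](OC(C)=O)[C@@H](C)C[C@]2(OC(C)=O)C(=O)[C@@H](C)/C=C/C(C)(C)C(=O)[C@H](O)[C@H]1OC(C)=O` gives > 100000 nM, a limit of the assay
- compound 2 `C=C1[C@H](OC(C)=O)[C@H]2[C@@H](OC(=O)c3ccccc3)[C@@H](C)C[C@]2(OC(C)=O)C(=O)[C@@H](C)/C=C/C(C)(C)C(=O)[C@H](O)[C@H]1OC(C)=O` gives > 100000 nM, a limit of the assay
- compound 3 `C=C1[C@H](OC(C)=O)CC(=O)C(C)(C)/C=C/[C@H](C)C(=O)[C@@]2(OC(C)=O)C[C@H](C)[C@H](OC(C)=O)[C@@H]2[C@H]1OC(=O)c1ccccc1` gives > 100000 nM, a limit of the assay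

All three compounds were tested in an ADME assay on MCF7 cells (Homo sapiens) for cytotoxicity, read by MTT assay, with a stated time of 48 h; a lower number here means a stronger inhibitor, a higher number a weaker inhibitor. Compound 1 reached only a limit there. Compound 2 likewise reached only a limit. Compound 3 also reached only a limit. Compound 3 differs from compound 1 by hydrogen in place of hydroxy on a saturated ring carbon. The step from compound 1 to compound 3 is a step that the two limits leave unreadable from compound 1 to compound 3, because both values sit at the limit of > 100000 nM in this assay, at which 3 of the 3 values shown sit. Compound 2 has the same atoms as compound 1 joined differently, and the difference between the two cores is not broken down here.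

Compound 4 `C=C1[C@H](OC(C)=O)CC(=O)C(C)(C)/C=C/[C@H](C)C(=O)[C@@]2(OC(C)=O)C[C@H](C)[C@H](OC(=O)c3ccccc3)[C@@H]2[C@H]1OC(C)=O` has not been measured in this assay. It differs from compound 2 by hydrogen in place of hydroxy on a saturated ring carbon. Within the data shown here, this is the same kind of change as the one from compound 1 to compound 3, but the surroundings are not identical: in compound 4 the place is three ring bonds from the ring atom that bears an acetoxy group, whereas in compound 3 that ring atom bears a benzoyloxy group.

The step from compound 2 to compound 4 in this assay is expected to be a step that the limit leaves unreadable from compound 2 to compound 4, resting on the fact that compound 2 reached only a limit, > 100000 nM, and that the matching change from compound 1 to compound 3 gave a step the two limits leave unreadable. Compound 4 is therefore estimated at 200000 nM, with a plausible range from 50000 nM to 1000000 nM, and most likely the assay will again report only a limit.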

Compound 4, half-maximal inhibitory concentration: 51100 nM
Compound 4: the middle estimate sits 3.9-fold (0.59 log units) above what was measured, and the stated range covers the measured number.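

In this assay, among these compounds, putting hydrogen in place of hydroxy on a saturated ring carbon of the core of compound 2 gives an at least 1.9-fold lower number from compound 2 to compound 4 (0.29 log units; that floor lies within the scatter), and this makes compound 4 the only one of the four compounds with a number rather than a limit. The value of compound 2, > 100000 nM, is a limit and not a number, so the true step may be larger, yet the printed floor alone does not show a change beyond the usual scatter of this kind of measurement. Whether the change carries from one core to the other stays unsettled, because the matching pair, compound 1 and compound 3, cannot be read, and a single readable pair makes no rule: the limit of > 100000 nM in this assay, at which 3 of the 4 values shown sit.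

The compounds shown leave open what other groups would do on that saturated ring carbon, since only hydroxy and hydrogen appear there, and an amine or a methoxy group could give a quite different number. They also leave open whether the acetoxy groups could be swapped for a longer chain ester, or the benzoyloxy group for a carboxylic acid, on the core of compound 4.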